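The source may report more compounds than this note shows. Statements on the series, on what has been measured and on what is new or still open speak of the compounds shown alone.

Compound 1 `CN(C)CCCn1c(N)c(-c2nc3ccccc3[nH]2)c2nc(C#N)c(C#N)nc21` in a functional assay on HeLa cells (Homo sapiens) for antiproliferative activity, read by MTT assay, with a stated time of 48 h (a higher number here means a weaker inhibitor, a lower number a stronger inhibitor), gives 25900 nM. Compound 2 `CCN(CC)CCCn1c(N)c(-c2nc3ccccc3[nH]2)c2nc(C#N)c(C#N)nc21` differs from compound 1 in one respect, (diethylamino in place of dimethylamino on a saturated chain carbon, three bonds along the chain from an aromatic nitrogen), and in this assay compound 2 gives 3150 nM; the step is an 8.2-fold lower number from compound 1 to compound 2 (0.91 log units; beyond the scatter). Compound 3 `CN(C)CCCn1c(N)c(-c2nc3cc(Cl)ccc3[nH]2)c2nc(C#N)c(C#N)nc21` rests on a different core, which differs from the core of compound 1 by chloro in place of hydrogen on an aromatic carbon; in this assay compound 3 gives 16500 nM, a step of a 1.6-fold lower number from compound 1 to compound 3 (0.20 log units; within the scatter). Compound 4 `CCN(CC)CCCn1c(N)c(-c2nc3cc(Cl)ccc3[nH]2)c2nc(C#N)c(C#N)nc21` has not yet been measured. It differs from compound 3 by diethylamino in place of dimethylamino on a saturated chain carbon, three bonds along the chain from an aromatic nitrogen, which is the same change as that made from compound 1 to compound 2, at the same place. Among the measured compounds shown here, only that one earlier example is available, and the two cores differ as noted, so the expectation carries real uncertainty. Still, compound 4 is expected to take a step of about a 6.6-fold lower number from compound 3 to compound 4 (0.82 log units; beyond the scatter) in this assay, resting on the step of an 8.2-fold lower number from compound 1 to compound 2 (0.91 log units; beyond the scatter). The estimate for compound 4 in this assay is therefore 2500 nM, expected to fall between 800 nM and 8000 nM.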

Compound 4, half-maximal inhibitory concentration: 24400 nM
For compound 4 the middle estimate is 9.8-fold (0.99 log units) below the measured one, and the stated range ends below it.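

In this assay, the change from dimethylamino to diethylamino does not carry from one core to the other: the same change on two cores in this assay, an 8.2-fold lower number (0.91 log units; beyond the scatter) from compound 1 to compound 2 and a 1.5-fold higher number (0.17 log units; within the scatter) from compound 3 to compound 4, 12-fold (1.08 log units) apart, beyond the scatter of two such steps. With chloro present, the same change gives a 1.5-fold higher number from compound 3 to compound 4 (0.17 log units; within the scatter), so the clear gain seen without chloro does not appear, and adding chloro to the diethylamino compound gives a 7.7-fold higher number from compound 2 to compound 4 (0.89 log units; beyond the scatter), a loss not matched on the dimethylamino pair: the same change on two cores in this assay, a 1.6-fold lower number (0.20 log units; within the scatter) from compound 1 to compound 3 and a 7.7-fold higher number (0.89 log units; beyond the scatter) from compound 2 to compound 4, 12-fold (1.08 log units) apart, beyond the scatter of two such steps. This shows that in these four compounds the effects of the two changes do not simply add, but a single square of compounds cannot explain why, nor tell which core's result would be the more typical for this series.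

From the compounds shown here alone, whether a ring amine such as morpholine in place of diethylamino, or a longer chain, would follow compound 2 or compound 4 remains open. Going by these compounds, it is also open whether fluoro or methoxy in place of chloro would cancel the diethylamino gain in the same way.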